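Compound 3 to compound 4: a phenyl swap

The source may hold more compounds than are shown below. What is called first, only, known or untested is meant among the compounds shown, and "the series" means these compounds.

In an ADME assay on MT4 cells (Homo sapiens) for cytotoxicity (a higher number here means that more compound is tolerated, a lower number that less compound is tolerated), compound 1 `COC(=O)N[C@H](C(=O)NN(CCC[C@@](O)(Cc1ccccc1)C(=O)N[C@H]1c2ccccc2C[C@H]1O)Cc1ccc(C#N)cc1)C(C)(C)C` reads > 10000 nM, a limit of the assay and not a number. Compound 2 `COC(=O)N[C@H](C(=O)NN(CCC[C@@](O)(Cc1ccccc1)C(=O)N[C@H]1c2ccccc2C[C@H]1O)Cc1ccc(N(C)C)cc1)C(C)(C)C` reads > 10000 nM, again a limit. Compound 3 `COC(=O)N[C@H](C(=O)NN(CCC[C@@](O)(Cc1ccccc1)C(=O)N[C@H]1c2ccccc2C[C@H]1O)Cc1ccc(-c2cn3ccsc3n2)cc1)C(C)(C)C` stands at > 10000 nM, also a limit. Compound 4 `COC(=O)N[C@H](C(=O)NN(CCC[C@@](O)(Cc1ccccc1)C(=O)N[C@H]1c2ccccc2C[C@H]1O)Cc1ccc(-c2ccccc2)cc1)C(C)(C)C` differs from compound 3 by a group of 6 heavy atoms (6 carbon; one six-membered aromatic ring of carbon only) in place of a group of 8 heavy atoms (5 carbon, 2 nitrogen, 1 sulfur; 2 five-membered aromatic rings with 2 hetero atoms each), on an aromatic carbon. Among the measured compounds shown here, three measured steps bear on this change: a step that the two limits leave unreadable from compound 1 to compound 2, a step that the two limits leave unreadable from compound 1 to compound 3 and a step that the two limits leave unreadable from compound 2 to compound 3. All three measured compounds sit at the limit of > 10000 nM in this assay, at which 3 of the 3 values shown sit, so no step beyond the scatter is expected for compound 4 in this assay. The expected change is a step that the limit leaves unreadable from compound 3 to compound 4. Compound 4 is estimated at 15000 nM, with an expected range from 7000 nM to 40000 nM.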

Compound 4, half-maximal cytotoxic concentration: 7500 nM
Estimate against measurement, compound 4: 2.0-fold (0.30 log units) above, and the stated range covers the measured number.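

In this assay, phenyl at this place gives the only reading among these compounds that is a number and not a limit. The steps are an at least 1.3-fold lower number from compound 3 to compound 4 (0.12 log units; that floor lies within the scatter), an at least 1.3-fold lower number from compound 2 to compound 4 (0.12 log units; that floor lies within the scatter) and an at least 1.3-fold lower number from compound 1 to compound 4 (0.12 log units; that floor lies within the scatter), so each is only a floor and none shows that phenyl lowers the tolerated concentration. The other compounds offer no number to set beside it: the limit of > 10000 nM in this assay, at which 3 of the 4 values shown sit. As far as these compounds go, how far compound 1, compound 2 and compound 3 truly lie beyond their limits stays open. So does what a carboxylic acid or a pyridine ring would read at this place.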